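A few compounds are considered here, and "the series" means these few. Any claim that something is new, unique, unknown or untested is made for them only; others in the source may bear on it.

Measured so far:

Compound 1 `COc1ccc(C2=NN(C3=NC(=O)/C(=C4\C(=O)Nc5ccc(Br)cc54)S3)C(c3ccc(OC)cc3)C2)cc1` gives 210 nM in a functional assay on cells (Cancer cell lines, Homo sapiens) for cytotoxicity, read by sulforhodamine B assay, with a stated time of 48 h; a lower number here means a stronger inhibitor of growth, a higher number a weaker inhibitor of growth.
Compound 2 `COc1ccc(C2CC(c3ccc4ccccc4c3)=NN2C2=NC(=O)/C(=C3\C(=O)Nc4ccc(Br)cc43)S2)cc1` gives 61 nM in this assay.
Compound 3 `COc1ccc(C2=NN(C3=NC(=O)/C(=C4\C(=O)Nc5ccccc54)S3)C(c3ccc(Cl)cc3)C2)cc1` gives 100000 nM in this assay.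

Compounds 1 and 2 share one core and differ in a single place: naphthalen-2-yl in place of 4-methoxyphenyl on a carbon with a double bond to nitrogen. That change brought a 3.4-fold lower number from compound 1 to compound 2 (0.54 log units; beyond the scatter), a gain in growth inhibition that is larger than the scatter of repeated measurements, though still modest.

Compound 3 stands apart. Its core differs from the core of compound 1 in more than one place, and the difference between the two cores is not broken down here. In this assay compound 3 is the weakest of the three measured compounds by a wide margin, its number lying far beyond the scatter from both compound 1 and compound 2.

Compound 4 `O=C1N=C(N2N=C(c3ccc4ccccc4c3)CC2c2ccc(Cl)cc2)S/C1=C1/C(=O)Nc2ccccc21` has not yet been measured. It differs from compound 3 in a single place: naphthalen-2-yl in place of 4-methoxyphenyl on a carbon with a double bond to nitrogen. Among the measured compounds shown here, this is the same kind of change as the one from compound 1 to compound 2, but the surroundings are not identical: in compound 3 the ring atom two ring bonds away bears a 4-chlorophenyl group, whereas in compound 1 it bears a 4-methoxyphenyl group.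

If the change behaves as it did from compound 1 to compound 2, compound 4 is expected to show a step of about a 3.3-fold lower number from compound 3 to compound 4 (0.52 log units; beyond the scatter) in this assay, resting on the size of a 3.4-fold lower number from compound 1 to compound 2 (0.54 log units; beyond the scatter). Because compound 3 starts from 100000 nM, however, the uncertainty is large, and the estimate for compound 4 is 30000 nM, with a range from 5000 nM to 100000 nM.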

Compound 4, concentration for 50% growth inhibition: 740 nM
The estimate for compound 4 lay 41-fold (1.61 log units) above the measured number; the whole stated range lies above it.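

In this assay, placing naphthalen-2-yl where 4-methoxyphenyl stood on the core of compound 3 gave a 140-fold lower number from compound 3 to compound 4 (2.13 log units; beyond the scatter), turning a compound with very little growth inhibition into one whose number lies much closer to those of compound 1 and compound 2. The change lowered the number on both cores, so its direction carried over, but its size did not: the same change on two cores in this assay, a 3.4-fold lower number (0.54 log units; beyond the scatter) from compound 1 to compound 2 and a 140-fold lower number (2.13 log units; beyond the scatter) from compound 3 to compound 4, 39-fold (1.59 log units) apart, beyond the scatter of two such steps. The cores of compound 1 and compound 3 differ in more than one place, and these two pairs alone do not show which difference sets the size of the step, nor do they predict its size on any further core.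

The compounds shown leave open what happens when the cores differ in one place only, for example a core carrying 4-chlorophenyl with the bromine and one carrying 4-methoxyphenyl without it, which would help separate the contribution of each group to the size of the step. Also open, from the compounds shown here alone, is whether the gain belongs to naphthalen-2-yl in particular, or whether another group on the carbon with a double bond to nitrogen, such as plain phenyl, naphthalen-1-yl or a pyridine ring, would give a step of similar size.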